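Nitrile in place of amide at the chain end

The source may report more compounds than this note shows. Statements on the series, on what has been measured and on what is new or still open speak of the compounds shown alone.

Compound 3 `CCCn1c(=O)n(CCC(N)=O)c(=O)c2[nH]cnc21` gives 31500 nM in an assay on Cerebral cortex for binding affinity to adenosine receptor A1 (Cavia porcellus), read by radioligand binding (a lower number here means a stronger inhibitor, a higher number a weaker inhibitor), the highest of the two numbers shown. Compound 1 `C=CCCn1c(=O)c2[nH]cnc2n(CCC)c1=O` gives 60 nM in this assay, and the step from compound 1 to compound 3 is a 530-fold higher number from compound 1 to compound 3 (2.72 log units; beyond the scatter). Compound 2 `CCCn1c(=O)n(CC(=O)O)c(=O)c2[nH]cnc21` gives only a limit, > 200000 nM, as told by the limit of > 200000 nM in this assay, at which 1 of the 3 values shown sits. The step from compound 2 to compound 3 is an at least 6.3-fold lower number from compound 2 to compound 3 (0.80 log units; beyond the scatter). Compound 4 `CCCn1c(=O)n(CCC#N)c(=O)c2[nH]cnc21` differs from compound 3 by cyano in place of carbamoyl on a saturated chain carbon, two bonds along the chain from an aromatic nitrogen. Both measured steps bear on this change, since each replaces or introduces a carbamoyl-bearing chain end; the cyano keeps one acceptor and drops the donor. A modest decrease in the number is expected, a 3.2-fold lower number from compound 3 to compound 4 (0.50 log units; beyond the scatter). Compound 4 is expected to give 10000 nM, between 3000 nM and 40000 nM.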

Compound 4, inhibition constant: 15900 nM
Estimate against measurement, compound 4: 1.6-fold (0.20 log units) below; measured number inside the range.
By their numbers in this assay, from the lowest: compound 1; then compounds 4 and 3 (each within the scatter of the next). At a limit, above all of these: compound 2.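

In this assay, cyano in place of carbamoyl gives a 2.0-fold lower number from compound 3 to compound 4 (0.30 log units; within the scatter), so dropping the hydrogen-bond donor at this chain end produces no change beyond the scatter. The gap to the vinyl-ended chain stays large, a 270-fold higher number from compound 1 to compound 4 (2.42 log units; beyond the scatter), so the nitrile does not recover what the amide end lost. The comparison with the carboxy compound, an at least 12-fold lower number from compound 2 to compound 4 (1.09 log units; beyond the scatter), rests on a limit and not a number: the limit of > 200000 nM in this assay, at which 1 of the 4 values shown sits.

Open, as far as these compounds go, is whether an amine or hydroxyl at the chain end, or a longer chain carrying the nitrile, would narrow the gap to compound 1. The compounds shown do not tell what sets that gap.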